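Swapping the aryl group on a sulfonamide nitrogen

The source may hold more compounds than are shown below. What is called first, only, known or untested is meant among the compounds shown, and "the series" means these compounds.

Measured so far:
compound 1 `CCc1ccccc1NS(=O)(=O)c1ccc(N2CCNC2=O)cc1` with 240 nM
compound 2 `Cc1cccc(NS(=O)(=O)c2ccc(N3CCNC3=O)cc2)c1` with 110 nM

Both compounds share a core that carries a sulfonamide nitrogen bearing an aromatic ring, and both were tested in a functional assay on HT-29 cells (Homo sapiens) for antiproliferative activity, read by sulforhodamine B assay, with a stated time of 48 h; a higher number here means a weaker inhibitor, a lower number a stronger inhibitor. Compound 2 gives 110 nM and stands lowest of the two numbers; its nearest neighbour is compound 1 with 240 nM. Among the measured compounds shown here, the single step between them, a 2.2-fold lower number from compound 1 to compound 2 (0.34 log units; beyond the scatter), exchanged the aromatic ring on that nitrogen.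

Compound 3 `O=C1NCCN1c1ccc(S(=O)(=O)Nc2ccc(Cl)cc2)cc1` is the unmeasured compound. It differs from compound 2 in one place: 4-chlorophenyl in place of 3-methylphenyl on a sulfonamide nitrogen. This is again a change of the aromatic ring on the sulfonamide nitrogen, so the step from compound 1 to compound 2 is the only one that bears on it. That step was modest, and nothing in the data says which way a chlorine-bearing ring will move the number. A step of the same modest size, in either direction, or none beyond the scatter, is therefore the reasonable expectation, and the estimated step is no change at the digits printed from compound 2 to compound 3 (within the scatter). Compound 3 is thus expected to give about 110 nM, within a range of 45 nM to 280 nM.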

Compound 3, half-maximal inhibitory concentration: 220 nM
The estimate for compound 3 lay 2.0-fold (0.30 log units) below the measured number; the measured number falls inside the stated range.
By their numbers in this assay, from the lowest: compounds 2, 3 and 1 (each within the scatter of the next, the first and the last beyond it).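

In this assay, the change to a chlorine-bearing ring gives a 2.0-fold higher number from compound 2 to compound 3 (0.30 log units; within the scatter) and, against the other measured compound, a 1.1-fold lower number from compound 1 to compound 3 (0.04 log units; within the scatter), so compound 3 cannot be told apart from either neighbour. Only the earlier step, a 2.2-fold lower number from compound 1 to compound 2 (0.34 log units; beyond the scatter), lies beyond the scatter, which means that 4-chlorophenyl on the sulfonamide nitrogen fits within the small spread already set by 2-ethylphenyl and 3-methylphenyl rather than extending it. Nothing available here gives a reason for these small differences.

The three rings differ both in which group they carry and in where it sits on the ring, so the compounds shown cannot separate those two influences; a pair such as 3-chlorophenyl and 4-chlorophenyl, or 3-methylphenyl and 4-methylphenyl, would hold one of them fixed. From the compounds shown here alone, it also remains open whether this flat response holds beyond singly substituted phenyl rings, for instance with a ring carrying a carboxylic acid or an amine, or with a non-aromatic cyclohexyl group on the sulfonamide nitrogen.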